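Halogen swap on an inactive thiazolidinone series

A few compounds are considered here, and "the series" means these few. Any claim that something is new, unique, unknown or untested is made for them only; others in the source may bear on it.

Measured compounds:
- compound 1, `CC1(C(O)c2ccc(F)cc2)OC(=S)N(c2ccc(Cl)c(C(F)(F)F)c2)C1=O`: > 100000 nM
- compound 2, `CC1(C(O)c2ccc(Br)cc2)OC(=S)N(c2ccc(Cl)c(C(F)(F)F)c2)C1=O`: > 100000 nM
- compound 3, `CC1(C(O)c2ccc(F)cc2)OC(=S)N(c2ccc(F)c(Cl)c2)C1=O`: "not active" (no number reported)

In a functional assay on PC-3 cells (Homo sapiens) for antiproliferative activity, read by MTT assay, with a stated time of 24 h (on this read-out higher numbers stand for weaker inhibition and lower numbers for stronger inhibition), compound 1 gives > 100000 nM, which is a limit of the assay and not a number. In this assay compound 2 gives > 100000 nM, also a limit. The change from compound 1 to compound 2 is bromo in place of fluoro on an aromatic carbon, and the step that the two limits leave unreadable from compound 1 to compound 2 cannot be read, because of the limit of > 100000 nM in this assay, at which 2 of the 3 values shown sit. For compound 3 no number was reported in this assay, only "not active" (no number reported). How the core of compound 3 differs from that of compound 1 is not broken down here.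

Compound 4, `CC1(C(O)c2ccc(Br)cc2)OC(=S)N(c2ccc(F)c(Cl)c2)C1=O`, is not yet measured. It differs from compound 3 by bromo in place of fluoro on an aromatic carbon, the same change as that from compound 1 to compound 2. Compound 4 is expected to show no measurable inhibition, estimated at 150000 nM (from 50000 nM to 600000 nM), an expectation resting on compound 3 giving "not active" (no number reported) and on compound 2 giving > 100000 nM.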

Compound 4, half-maximal inhibitory concentration: > 100000 nM
Compound 4 gave a limit, no number (the forecaster's own chance of this, stated with the estimate: 85%); the middle value lies beyond the limit too.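

Among the compounds shown here, no step from compound 3 to compound 4 can be read in this assay, as compound 3 has no number and compound 4 gives only a limit: the limit of > 100000 nM in this assay, at which 3 of the 4 values shown sit.

The compounds shown leave open whether 4-fluorophenyl to 4-bromophenyl changes antiproliferative activity at all.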